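From a Sulfur-Bearing Chain to a Branched Alkyl Ether

The source may report more compounds than this note shows. Statements on the series, on what has been measured and on what is new or still open speak of the compounds shown alone.

Compound 3, `CSCCOc1cccc2ccc(N)nc12`, carries a 2-(methylsulfanyl)ethyl group on an oxygen on an aromatic ring of the shared core. In an assay on cells with melanin-concentrating hormone receptor 1 (Homo sapiens) as the target, read by radioligand binding (on this read-out higher numbers stand for weaker inhibition and lower numbers for stronger inhibition), compound 3 gives only a limit, > 2000 nM, rather than a number (the limit of > 2000 nM in this assay, at which 1 of the 3 values shown sits). Compound 1, `CCC(C)COc1cccc2ccc(N)nc12`, with a sec-butyl group on that oxygen, gives 36 nM in this assay, and compound 2, `CCCCCOc1cccc2ccc(N)nc12`, with butyl in place of sec-butyl, gives 580 nM. The step from the branched to the straight chain is large: a 16-fold higher number from compound 1 to compound 2 (1.21 log units; beyond the scatter). The step from the branched group to the sulfur-bearing chain is larger still: an at least 55-fold higher number from compound 1 to compound 3 (1.74 log units; beyond the scatter), and even against the straight chain the sulfur-bearing chain loses ground: an at least 3.4-fold higher number from compound 2 to compound 3 (0.53 log units; beyond the scatter).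

Compound 4, `CC(C)C(C)Oc1cccc2ccc(N)nc12`, has not been measured. Its change from compound 3 is 1,2-dimethylpropyl in place of 2-(methylsulfanyl)ethyl on an oxygen on an aromatic ring. The entering group is branched on the carbon bound to the oxygen, as sec-butyl in compound 1 is, and is made of carbon only. Both steps leading away from compound 1 point the same way, so a large move toward stronger inhibition is expected here. For compound 4 the expected value in this assay is 50 nM, within a range from 15 nM to 200 nM. The expected step is an at least 40-fold lower number from compound 3 to compound 4 (1.60 log units; beyond the scatter).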

Compound 4, half-maximal inhibitory concentration: 199 nM
Compound 4: middle estimate off by 4.0-fold (0.60 log units), on the low side; measured number inside the range.
By their numbers in this assay, from the lowest: compound 1; then compound 4; then compound 2. At a limit, above all of these: compound 3.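

In this assay, the all-carbon 1,2-dimethylpropyl group on this oxygen gives a real number where the 2-(methylsulfanyl)ethyl group did not, an at least 10-fold lower number from compound 3 to compound 4 (1.00 log units; beyond the scatter), but this step is only a bound, as compound 3 sits at a limit: the limit of > 2000 nM in this assay, at which 1 of the 4 values shown sits. A branched chain also does better than the straight pentyl chain of the same heavy-atom size class, with a 2.9-fold lower number from compound 2 to compound 4 (0.46 log units; beyond the scatter), so compound 1 is no longer the only branched ether to outdo that straight chain. Even so, the two branched groups are not interchangeable: with a 5.5-fold higher number from compound 1 to compound 4 (0.74 log units; beyond the scatter), the 2-methylbutyl group stays ahead, which shows that the particular branched group matters, not only the presence of a branch.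

The compounds shown leave open whether a ring on this oxygen, such as cyclopentyl, or a longer branched chain would match or pass the 2-methylbutyl group. They also do not separate the effect of the sulfur atom in compound 3 from that of the chain carrying it, a question on which a 2-methoxyethyl group would bear.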